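Shared-core series: terminal chain change and cytotoxicity

The source may report more compounds than this note shows. Statements on the series, on what has been measured and on what is new or still open speak of the compounds shown alone.

Compound 1 `NCCCc1ccc(-c2ccc(-c3ccc(-c4cccs4)s3)s2)s1`: > 200000 nM
Compound 2 `BrCCCCc1ccc(-c2ccc(-c3ccc(-c4cccs4)s3)s2)s1`: "not determined" (no result reported)
Compound 3 `[N-]=[N+]=NCCCCc1ccc(-c2ccc(-c3ccc(-c4cccs4)s3)s2)s1`: "not determined" (no result reported)

In an ADME assay on MDCK cells (Canis lupus familiaris) for cytotoxicity, read by MTT assay, with a stated time of 2 days (on this read-out higher numbers stand for lower toxicity in this test and lower numbers for higher toxicity in this test), compound 1 gives > 200000 nM, which is a limit of the assay rather than a number. Compound 2 has no result in this assay ("not determined" (no result reported)), and compound 3 likewise has none ("not determined" (no result reported)). Among the compounds with values here, compound 2 thus stands with no single number, and the only value on the shared core is the limit of compound 1 (the limit of > 200000 nM in this assay, at which 1 of the 3 values shown sits). Compound 4 `BrCCCCc1ccc(-c2ccc(-c3ccc(CCCCBr)s3)s2)s1` differs from compound 2 by 4-bromobutyl in place of thiophen-2-yl on an aromatic carbon. Within the data shown here, with no measured step available for comparison, no step beyond the scatter is expected in this assay in either direction. Compound 4 is accordingly expected to give 200000 nM, with a range from 50000 nM to 300000 nM, most likely reported again only as a limit.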

Compound 4, half-maximal cytotoxic concentration: > 200000 nM
Compound 4 was reported as a limit; the forecaster's own chance of this, stated with the estimate: 70%; the middle value lies on the limit itself.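

In this assay compound 4 gives > 200000 nM, a limit of the assay and not a number. Within the data shown here, no step from compound 2 to compound 4 can be read. The compounds shown leave open whether 4-bromobutyl in place of thiophen-2-yl changes the read-out of this assay on the shared core.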